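Piperazine substituent change in the benzamide series

The source may hold more compounds than are shown below. What is called first, only, known or untested is meant among the compounds shown, and "the series" means these compounds.

Compound 1 `Nc1ccccc1NC(=O)c1ccc(CSC(=S)N2CCN(C3CCCCC3)CC2)cc1`, compound 2 `Nc1ccccc1NC(=O)c1ccc(CSC(=S)N2CCN(c3ccncc3)CC2)cc1` and compound 3 `Nc1ccccc1NC(=O)c1ccc(CSC(=S)N2CCN(c3ccc(F)cc3)CC2)cc1` share one core and differ only in the group on an amine nitrogen in a ring. In a functional assay on MGC-803 cells (Homo sapiens) for antiproliferative activity, read by CCK-8 assay, with a stated time of 72 h, tested at 2 uM (on this read-out higher numbers stand for a stronger effect at the one concentration tested and lower numbers for a weaker effect), compound 1 gives 16.9%, compound 2 gives 64.8% and compound 3 gives 18.8%. Compound 3 stands second highest of the three, close to compound 1 and far below compound 2. Compound 4 `Nc1ccccc1NC(=O)c1ccc(CSC(=S)N2CCN(c3ncccn3)CC2)cc1` carries pyrimidin-2-yl in place of 4-fluorophenyl on an amine nitrogen in a ring. The bearing steps are a number 1.9 percentage points higher from compound 1 to compound 3 (within the scatter) and a number 46 percentage points lower from compound 2 to compound 3 (beyond the scatter); a ring with two nitrogen atoms enters, and the only measured aza-aromatic ring, in compound 2, gave a number 47.9 percentage points higher from compound 1 to compound 2 (beyond the scatter). For the measured compounds named here, an upward step in this assay is therefore expected, estimated as a number 26.2 percentage points higher from compound 3 to compound 4 (beyond the scatter), though only one such example exists. Compound 4 is estimated at 45%, within 20% to 70%.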

Compound 4, a percentage reported as inhibition, at one concentration (the size of the read-out at that concentration, not a potency): 28.4%
Compound 4: the middle estimate sits 16.6 percentage points above what was measured; the range from low to high includes it.
By their numbers in this assay, from the lowest: compounds 1, 3 and 4 (each within the scatter of the next, the first and the last beyond it); then compound 2.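

In this assay a second aza-aromatic ring does not repeat the result of pyridin-4-yl: the change to pyrimidin-2-yl gives a number 36.4 percentage points lower from compound 2 to compound 4 (beyond the scatter). Against the carbon-only rings the picture is split, with a number 9.6 percentage points higher from compound 3 to compound 4 (within the scatter) and a number 11.5 percentage points higher from compound 1 to compound 4 (beyond the scatter), so among these compounds nitrogen in the aromatic ring does not by itself match compound 2. Nothing available explains the gap between the two aza-aromatic rings.

Open, going by these compounds, is whether pyridin-3-yl or pyridin-2-yl on this amine nitrogen stays with compound 2 or with compound 4. Also open, on these data alone, is how a small group such as methyl or acetyl compares there.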